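Fluoro for nitro: one measured step, one to come

The compounds below may be only part of what the source reports. "The series", "measured", "known", "first", "only" and "open" are said of these compounds alone.

Compound 1 `COc1cc(/C=C/C(=O)c2ccccc2[N+](=O)[O-])cc(OC)c1` gives 3700 nM in a functional assay (Homo sapiens) for inhibition; on this read-out lower numbers stand for stronger inhibition and higher numbers for weaker inhibition. Compound 2 `COc1cc(/C=C/C(=O)c2ccccc2F)cc(OC)c1` differs from it by fluoro in place of nitro on an aromatic carbon, and in this assay compound 2 gives 6000 nM. This change made a 1.6-fold higher number from compound 1 to compound 2 (0.21 log units; within the scatter). Compound 3 `COc1ccc(C(=O)/C=C/c2ccccc2[N+](=O)[O-])c(OC)c1OC` gives 7000 nM in this assay; the difference between its core and the core of compound 1 is not broken down here, and the two values lie within the scatter of each other. Compound 4 `COc1ccc(C(=O)/C=C/c2ccccc2F)c(OC)c1OC` carries the same change relative to compound 3, (fluoro in place of nitro on an aromatic carbon), with the place described in the same words. Because the measured step made a 1.6-fold higher number from compound 1 to compound 2 (0.21 log units; within the scatter), a step of similar size is expected for compound 4, a 1.6-fold higher number from compound 3 to compound 4 (0.20 log units; within the scatter). Compound 4 is therefore estimated at 11000 nM in this assay, expected to fall between 4500 nM and 28000 nM.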

Compound 4, half-maximal inhibitory concentration: 11000 nM
Compound 4: the middle estimate sits on the measured number at the digits printed, within the range that was stated.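

In this assay, the new step is a 1.6-fold higher number from compound 3 to compound 4 (0.20 log units; within the scatter), and the two steps for fluoro in place of nitro agree across the two cores: the same change on two cores in this assay, a 1.6-fold higher number (0.21 log units; within the scatter) from compound 1 to compound 2 and a 1.6-fold higher number (0.20 log units; within the scatter) from compound 3 to compound 4, 1.0-fold (0.01 log units) apart, within the scatter of two such steps. Both steps lie within the scatter, so the pair does not establish that fluoro and nitro differ at all in this read-out. For the compounds shown here, the agreement shows only that the change behaves alike on these two cores, and two cores give no basis for a rule across the series.

The compounds shown leave open how an amine, a carboxylic acid or a nitrile would compare with fluoro and nitro at this place. From the compounds shown here alone, whether any replacement there gives a step beyond the scatter also remains open.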